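The compounds below may be only part of what the source reports. "The series", "measured", "known", "first", "only" and "open" are said of these compounds alone.

Working notes. Within the data shown here, compound 2 `COc1ccccc1-n1nc(C2CCOC(C)(C)C2)cc1-c1ccc(Cl)cc1` holds the higher of the two numbers measured so far in an assay on HEK293 cells for inhibition of Voltage-dependent N-type calcium channel subunit alpha-1B (Homo sapiens), read by patch clamp, using a membrane potential dye (on this read-out lower numbers stand for stronger inhibition and higher numbers for weaker inhibition), giving 55 nM. Compound 1 `COc1ccccc1-n1nc([C@H]2C[C@@H](C)O[C@@H](C)C2)cc1-c1ccc(Cl)cc1` gives 12 nM in this assay. Compound 3 `COc1ccccc1-n1nc(C2C[C@H](C)O[C@@H](C)C2)cc1-c1ccc(Cl)cc1` differs from compound 2 by 2,6-dimethyloxan-4-yl in place of 2,2-dimethyloxan-4-yl on an aromatic carbon. Among the measured compounds shown here, the one step that bears on this change is a 4.6-fold higher number from compound 1 to compound 2 (0.66 log units; beyond the scatter), which runs the opposite way, so compound 3 is expected to come back toward compound 1, by a step of a 3.7-fold lower number from compound 2 to compound 3 (0.56 log units; beyond the scatter). The estimate for compound 3 in this assay is therefore 15 nM, with a range of 6 nM to 50 nM.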

Compound 3, half-maximal inhibitory concentration: 61000 nM
Compound 3: the middle estimate sits 4100-fold (3.61 log units) below what was measured; measured number above the stated range.
By their numbers in this assay, from the lowest: compound 1; then compound 2; then compound 3.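

In this assay, the name 2,6-dimethyloxan-4-yl does not fix the outcome at this position: replacing 2,2-dimethyloxan-4-yl with it gives a 1100-fold higher number from compound 2 to compound 3 (3.04 log units; beyond the scatter), the opposite direction to compound 1. With atoms and bonds identical, only the drawn stereo elements separate the pair in a 5100-fold higher number from compound 1 to compound 3 (3.71 log units; beyond the scatter), and one limit applies to this comparison: the fact that one of compounds 1 and 3 is drawn with a defined configuration and the other without, at the place where they differ.

From the compounds shown here alone, what each single configuration at the undefined ring carbon of compound 3 would give remains open. So does the outcome with a piperidine, an amine nitrogen replacing the ring oxygen.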